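A few compounds are considered here, and "the series" means these few. Any claim that something is new, unique, unknown or untested is made for them only; others in the source may bear on it.

Working notes on the series. Among the measured compounds shown here, in an assay (Cricetulus griseus) for inhibition of aldehyde dehydrogenase, mitochondrial (Homo sapiens) (a lower number here means a stronger inhibitor, a higher number a weaker inhibitor), compound 1 `CCCCCCOc1ccc2c(=O)c(-c3ccc(O)cc3)coc2c1` gives 1500 nM, and compound 2 `O=C(O)CCCCCCCCCOc1ccc2c(=O)c(-c3ccc(O)cc3)coc2c1` gives 50 nM; compound 2 thus holds the lowest number of the two values at hand, and the single step recorded, a 30-fold lower number from compound 1 to compound 2 (1.48 log units; beyond the scatter), is large. Compound 3 `O=C(O)CCCCCCOc1ccc2c(=O)c(-c3ccc(O)cc3)coc2c1` is the next member: the change from compound 2 is carboxy in place of 3-carboxypropyl on a saturated chain carbon, six bonds along the chain from an oxygen on an aromatic ring. For the measured compounds named here, only the step from compound 1 to compound 2 bears on this; it shows that a chain carrying a terminal carboxylic acid gives a far lower number than the plain hexyl chain of compound 1. Going by the values given here, compound 3 keeps the acid but with a shorter chain, so the expectation is a number between those of compound 1 and compound 2, read as a moderate rise from compound 2, a 6.0-fold higher number from compound 2 to compound 3 (0.78 log units; beyond the scatter), with wide uncertainty because the shortened chain has no measured counterpart. The expected value for compound 3 in this assay is 300 nM, within 80 nM to 1200 nM.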

Compound 3, half-maximal inhibitory concentration: 50 nM
Compound 3: the middle estimate sits 6.0-fold (0.78 log units) above what was measured, and the stated range ends above it.
By their numbers in this assay, from the lowest: compounds 2 and 3 (each within the scatter of the next); then compound 1.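

In this assay, no change at the digits printed from compound 2 to compound 3 (within the scatter), so at this chain carbon, six bonds along the chain from an oxygen on an aromatic ring, carboxy serves as well as 3-carboxypropyl, and the longer chain of compound 2 adds nothing measurable. Read against the plain hexyl chain, a 30-fold lower number from compound 1 to compound 3 (1.48 log units; beyond the scatter), so the whole of the large drop seen with compound 2 is also reached with the shorter acid-bearing chain of compound 3. Nothing at hand accounts for this flat response to chain length.

The acid-bearing chains shown are only those of compound 2 and compound 3, so it remains open whether a shorter chain ending in a carboxylic acid keeps the low number. Also open, from the compounds shown here alone, is whether a methyl ester, a primary amide or an amine at the chain end can stand in for the carboxy group.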